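Indole sulfonamides: naphthalene attachment point, compound 3 to compound 4

The source may hold more compounds than are shown below. What is called first, only, known or untested is meant among the compounds shown, and "the series" means these compounds.

Measured compounds so far:
- compound 1, `CN(C)CCn1ccc2cc(NS(=O)(=O)c3cccc4ccccc34)ccc21` — 94.2 nM
- compound 2, `CCN(CC)CCn1ccc2cc(NS(=O)(=O)c3c(Cl)nc4sccn34)ccc21` — 97.3 nM
- compound 3, `CCN(CC)CCn1ccc2cc(NS(=O)(=O)c3cccc4ccccc34)ccc21` — 116 nM

All three were read in an assay on HEK293 cells for binding affinity to 5-hydroxytryptamine receptor 6 (Homo sapiens); on this read-out higher numbers stand for weaker inhibition and lower numbers for stronger inhibition. Compound 3 holds the highest of the three numbers, but its gaps to the others are small: a 1.2-fold higher number from compound 1 to compound 3 (0.09 log units; within the scatter) and a 1.2-fold higher number from compound 2 to compound 3 (0.08 log units; within the scatter). Both of those steps, the change at the amine and the change of the group on the sulfonyl sulfur, sit within the scatter, so on the numbers shown the three compounds cannot be set in order.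

The next compound, compound 4, `CCN(CC)CCn1ccc2cc(NS(=O)(=O)c3ccc4ccccc4c3)ccc21`, differs from compound 3 only in how the same atoms are joined: naphthalen-2-yl in place of naphthalen-1-yl on a sulfonyl sulfur. Neither measured step bears directly on this change; the step from compound 2 to compound 3 swaps the whole group on the sulfonyl sulfur, and the step from compound 1 to compound 3 touches the amine, so nothing measured here speaks to moving the attachment point within the same two-ring group. Both known changes on this core moved the number by less than the scatter, which gives no reason to expect a large shift, but also no direction.

The working expectation for compound 4 is therefore a step of about a 1.1-fold lower number from compound 3 to compound 4 (0.02 log units; within the scatter) in this assay, that is, no change beyond the scatter, with a wide range to cover the unknown. Compound 4 is estimated at 110 nM, between 30 nM and 450 nM.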

Compound 4, inhibition constant: 141 nM
Estimate against measurement, compound 4: 1.3-fold (0.11 log units) below; the measured number falls inside the stated range.
By their numbers in this assay, from the lowest: compounds 1, 2, 3 and 4 (each within the scatter of the next).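

In this assay, moving the attachment on the sulfonyl sulfur from naphthalen-1-yl to naphthalen-2-yl gives a 1.2-fold higher number from compound 3 to compound 4 (0.08 log units; within the scatter), so the first direct read on this change does not separate the two attachment points. The earlier steps shown here changed the amine or replaced the whole group on the sulfonyl sulfur, whereas this one keeps the same atoms and shows that rejoining them leaves the number within the scatter. Compound 4 also gives a 1.4-fold higher number from compound 2 to compound 4 (0.16 log units; within the scatter), so neither naphthalene attachment is separated from the group on the sulfonyl sulfur in compound 2, and no measurement here bears further on this result.

It remains open whether any group on the sulfonyl sulfur can move the number beyond the scatter, since every such group shown has two aromatic rings and a single phenyl ring would be a natural test of that limit. Also open, going by these compounds, is whether naphthalen-2-yl reads the same with dimethylamino in place of diethylamino on the chain, or with a piperidine ring at that amine.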